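From Ethoxycarbonyl to Dimethylcarbamoyl at the Assay Limit

The source may report more compounds than this note shows. Statements on the series, on what has been measured and on what is new or still open speak of the compounds shown alone.

Compound 1 `Cc1cc(-c2noc(C(F)(F)F)n2)cc(C)c1OCCCc1cc(C(=O)NCc2ccccc2)no1`: > 100000 nM
Compound 2 `CCOC(=O)c1cc(CCCOc2ccc(-c3noc(C(F)(F)F)n3)cn2)on1`: > 100000 nM

Both results come from an ADME assay on HeLa cells (Homo sapiens) for cytotoxicity, read by crystal violet staining, with a stated time of 72 h (a higher number here means that more compound is tolerated, a lower number that less compound is tolerated), and neither is an exact number. Compound 1 gives > 100000 nM, which is a limit of the assay. Compound 2 gives > 100000 nM, which is also a limit, so its true position is not known.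

Compound 3 `CN(C)C(=O)c1cc(CCCOc2ccc(-c3noc(C(F)(F)F)n3)cn2)on1` differs from compound 2 in one place: dimethylamino in place of ethoxy on a carbonyl carbon. Dimethylamino stands in place of ethoxy on a carbonyl carbon, so ethoxycarbonyl becomes dimethylcarbamoyl. Going by the values given here, no measured pair shows what a change like this does in this assay, so the only anchor is compound 2 with > 100000 nM. Expected here is a number no higher from compound 2 to compound 3 (the limit leaves the size open), with no shift in either direction beyond the usual scatter. Another limit rather than a number is the likeliest report. For compound 3 the estimate is 100000 nM, with an expected range of 30000 nM to 300000 nM.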

Compound 3, half-maximal cytotoxic concentration: 48800 nM
Compound 3: middle estimate off by 2.0-fold (0.31 log units), on the high side, within the range that was stated.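

In this assay, dimethylamino in place of ethoxy on a carbonyl carbon gives an at least 2.0-fold lower number from compound 2 to compound 3 (0.31 log units; beyond the scatter). This shows that the group on this carbonyl carbon can matter: the change leads to a real number, with compound 3 at 48800 nM. The step could be larger than printed, and its full size cannot be read, because its starting point is only a limit: the limit of > 100000 nM in this assay, at which 2 of the 3 values shown sit.

Going by these compounds, how other groups would read at this place remains open, for example a smaller methylamino group, a ring amine such as morpholine, or a free carboxylic acid. A single step also cannot tell whether the same swap would lower the number on a different core, such as the core of compound 1.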